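Aryl-amine variation in the electroshock screen

The compounds below may be only part of what the source reports. "The series", "measured", "known", "first", "only" and "open" are said of these compounds alone.

Compound 1 `CCC(C(=O)N1CCN(c2ccccc2Cl)CC1)N1C(=O)CCC1=O`, compound 2 `CCC(C(=O)N1CCN(c2cccc(OC)c2)CC1)N1C(=O)CCC1=O` and compound 3 `CCC(C(=O)N1CCN(c2ccc(F)cc2)CC1)N1C(=O)CCC1=O` share one core and differ only in the aryl group carried by the ring amine nitrogen. In a functional assay on the whole organism (strain Swiss) with Mus musculus as the target, in the maximal electroshock model, with a stated time of 2 h, at a dose of 300 mg/kg by the intraperitoneal route (on this read-out higher numbers stand for a stronger effect at the one dose given and lower numbers for a weaker effect), compound 1 gives 0%, compound 2 gives 0% and compound 3 gives 0%. Compound 3 therefore stands level with compounds 1 and 2 at the digits shown: the steps of no change at the digits printed from compound 1 to compound 3 (within the scatter) and no change at the digits printed from compound 2 to compound 3 (within the scatter) both lie within the scatter, as does no change at the digits printed from compound 1 to compound 2 (within the scatter). Compound 4 `CCC(C(=O)N1CCN(c2ccccc2F)CC1)N1C(=O)CCC1=O` has not yet been measured; it differs from compound 3 as follows: 2-fluorophenyl in place of 4-fluorophenyl on an amine nitrogen in a ring. Going by the values given here, the steps that bear on this change are those exchanging the aryl group on the same nitrogen, no change at the digits printed from compound 1 to compound 3 (within the scatter) and no change at the digits printed from compound 2 to compound 3 (within the scatter), and neither moved the read-out beyond the scatter. In this assay no step beyond the scatter is expected from this change either. Compound 4 is accordingly estimated at 0%, with a range from 0% to 15%. The step this estimate implies is no change at the digits printed from compound 3 to compound 4 (within the scatter), expected to be within the scatter.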

Compound 4, a percentage reported as activity, at one dose (the size of the read-out at that dose, not a potency): 0%
Compound 4: middle estimate and measured number agree at the digits printed; the measured number falls inside the stated range.
By their numbers in this assay, from the lowest: compounds 1, 2, 3 and 4 (each within the scatter of the next).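

In this assay, the new pair isolates the placement of the fluoro group on the aryl ring, since the two groups have the same atoms joined differently, and the result is no change at the digits printed from compound 3 to compound 4 (within the scatter). Exchanging the halogen alone gives no change at the digits printed from compound 1 to compound 4 (within the scatter), and replacing 3-methoxyphenyl gives no change at the digits printed from compound 2 to compound 4 (within the scatter), so neither fluoro placement nor fluoro in place of chloro produces a detectable effect in these compounds at the one dose given. Nothing available explains this flat result.

With no effect seen for any of the four compounds, the read-out cannot separate these aryl groups. Still open, going by these compounds, is whether a benzyl group on the same amine nitrogen, or a longer chain in place of the ethyl group of the shared core, would give a measurable effect.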